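This account rests on a few compounds, and the source may have more. Where it says the series, first, only, none or still open, it means among the compounds named here.

Measured compounds:
- compound 1 `CN(C)C(=O)c1cc2cnc(Nc3ccc(NC(=O)C4(C(=O)Nc5cccc(O)c5)CC4)cc3)nc2n1C1CCCC1`: 80.7%
- compound 2 `CN(C)C(=O)c1cc2cnc(Nc3ccc(NC(=O)C4(C(=O)Nc5ccccc5F)CC4)cc3)nc2n1C1CCCC1`: 85.2%

Compound 1 stands lowest of the two numbers measured in a functional assay on T47D cells (Homo sapiens) for inhibition, read by CCK-8 assay, with a stated time of 72 h, tested at 1 uM (on this read-out higher numbers stand for more inhibition of growth at the one concentration tested and lower numbers for less inhibition of growth), and its nearest neighbour is compound 2, with a step of a number 4.5 percentage points higher from compound 1 to compound 2 (within the scatter), so the two compounds cannot be told apart on this read-out.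

Compound 3 `CN(C)C(=O)c1cc2cnc(Nc3ccc(NC(=O)C4(C(=O)Nc5ccccc5)CC4)cc3)nc2n1C1CCCC1` differs from compound 1 in one place: hydrogen in place of hydroxy on an aromatic carbon. Among the compounds with values here, the one measured step, from 3-hydroxyphenyl to 2-fluorophenyl on the amide-type nitrogen, changed the read-out by a number 4.5 percentage points higher from compound 1 to compound 2 (within the scatter); it swaps the same aryl group, but both the hydroxy and the fluorine are exchanged at once, so it bears on the present change only loosely. It does show that varying the substituent on this phenyl ring leaves the result within the scatter. Removing the hydroxy alone is therefore expected to give no step beyond the scatter, the estimated step being a number 1.3 percentage points higher from compound 1 to compound 3 (within the scatter).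

For compound 3 the expected result in this assay is 82%, within a range from 70% to 92%.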

Compound 3, percent growth inhibition at one concentration: 52.8%
Compound 3: middle estimate off by 29.2 percentage points, on the high side; the measured number lies below the stated range.
By their numbers in this assay, from the lowest: compound 3; then compounds 1 and 2 (each within the scatter of the next).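

In this assay, hydrogen in place of hydroxy on the aromatic carbon gives a number 27.9 percentage points lower from compound 1 to compound 3 (beyond the scatter), and hydrogen in place of fluoro gives a number 32.4 percentage points lower from compound 2 to compound 3 (beyond the scatter). The earlier pair had a substituent on this phenyl ring in both compounds, so it could only suggest that the ring tolerates change; the plain phenyl now shows that the read-out does depend on this ring carrying a substituent, at least for the 3-hydroxyphenyl and 2-fluorophenyl groups. No measurement shown here accounts for the drop or says what the hydroxy and the fluoro have in common in this read-out.

From the compounds shown here alone, the 3-hydroxyphenyl and 2-fluorophenyl groups differ in both the substituent and its place on the ring, so it remains open whether the group, its place or simply the presence of a substituent sets the level. Also open, going by these compounds, is whether a methoxy group, a chlorine atom or an amine on the same ring would hold the read-out at the level of the two substituted compounds, and how the three compounds would compare at other concentrations.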